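The source may hold more compounds than are shown below. What is called first, only, known or untested is meant among the compounds shown, and "the series" means these compounds.

Working notes on the series.

Of the compounds shown here, three sharing one core have been measured in an assay on HEK293 cells for inhibition of Fatty-acid amide hydrolase 1 (Homo sapiens), read by fluorescence; a lower number here means a stronger inhibitor, a higher number a weaker inhibitor. Within the data shown here, compound 1 `CCn1ccc2cc(-c3ccc4oc(NC5CCCCC5)nc4c3)ccc21` gives 207 nM, and compound 2 `NC(=O)Cn1ccc2cc(-c3ccc4oc(NC5CCCCC5)nc4c3)ccc21` gives 214 nM; the only one-point step so far, a 1.0-fold higher number from compound 1 to compound 2 (0.01 log units; within the scatter), sits at the chain on the aromatic nitrogen and leaves the number unchanged. Compound 3 `Cn1ccc2cc(-c3ccc4oc(Nc5ccc(F)cc5)nc4c3)ccc21` gives 99 nM, the lowest of the three numbers, with compound 1 the nearest and compound 2 the furthest, both beyond the scatter.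

The next compound, compound 4 `Cn1ccc2cc(-c3ccc4oc(N5CCNCC5)nc4c3)ccc21`, differs from compound 3 only at the substituent on the five-membered ring: piperazin-1-yl in place of (4-fluorophenyl)amino on an aromatic carbon. Among the measured compounds shown here, no measured step touches this position; the single step in hand concerns a different site and is within the scatter, so it gives no guidance on size or direction. What is known is that the two amines placed here so far (cyclohexylamino in compound 1 and compound 2, (4-fluorophenyl)amino in compound 3) span only a modest spread. Removing the aryl ring and the attached hydrogen-bond donor is a larger change than any seen, so a weaker inhibitor is expected, by about a 4.0-fold higher number from compound 3 to compound 4 (0.61 log units; beyond the scatter), with wide uncertainty. Compound 4 is thus estimated at 400 nM, between 100 nM and 1600 nM.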

Compound 4, half-maximal inhibitory concentration: > 1000 nM
Compound 4: a limit, no number; the forecaster's own chance of this, stated with the estimate: 10%; middle value at least 2.5-fold (0.39 log units) from the limit.
By their numbers in this assay, from the lowest: compound 3; then compounds 1 and 2 (each within the scatter of the next). At a limit, above all of these: compound 4.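

In this assay compound 4 reads > 1000 nM, which is a limit of the assay and not a number: the limit of > 1000 nM in this assay, at which 1 of the 4 values shown sits.

Among these compounds, the swap of piperazin-1-yl for (4-fluorophenyl)amino gives an at least 10-fold higher number from compound 3 to compound 4 (1.00 log units; beyond the scatter), so the group on this aromatic carbon can move the read-out beyond the scatter, which the only earlier step, a 1.0-fold higher number from compound 1 to compound 2 (0.01 log units; within the scatter), at a different site, could not show. The two groups count the same hydrogen-bond donors, so the step does not come with a change in that count, while a six-membered aromatic ring of carbon only gives way to a non-aromatic ring with 2 hetero atoms.

The compounds shown do not separate the loss of the aromatic ring from the change in how the ring is attached. Going by these compounds, a 4-phenylpiperazin-1-yl or a morpholin-4-yl group here would bear on that, and how far the step extends beyond the limit stays open.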